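The source may hold more compounds than are shown below. What is called first, only, known or untested is meant among the compounds shown, and "the series" means these compounds.

Measured compounds:
compound 1 `Cc1ccc(S(=O)(=O)Nc2ccc(-c3nc4ccccc4o3)cc2)cc1`: > 100000 nM
compound 2 `COc1cccc(S(=O)(=O)Nc2ccc3oc(-c4ccccc4)nc3c2)c1`: > 100000 nM

Both numbers come from an assay on cells for inhibition of HSP60/HSP10 (Homo sapiens), with a stated time of 60 min; a higher number here means a weaker inhibitor, a lower number a stronger inhibitor. Compound 1 stands at a limit there: its value of > 100000 nM is the edge of what the test can report, not a measured number. Compound 2 sits at the same kind of limit, with > 100000 nM. So far, then, (the limit of > 100000 nM in this assay, at which 2 of the 2 values shown sit), and nothing about either compound can be ranked against the other.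

Compound 3 `COc1ccc(Cl)cc1S(=O)(=O)Nc1ccc(-c2nc3ccccc3o2)cc1` differs from compound 1 in one place: 5-chloro-2-methoxyphenyl in place of 4-methylphenyl on a sulfonyl sulfur. For the measured compounds named here, no pair of measured compounds differing in one place exists here, so no measured step gives a size to expect. With compound 1 at a limit, the expectation for this change in this assay is no shift beyond the scatter, and compound 3 is expected to stay at or near that same limit. Compound 3 is estimated at 150000 nM, with a range from 40000 nM to 500000 nM, and the expected step that the limit leaves unreadable from compound 1 to compound 3 is essentially none.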

Compound 3, half-maximal inhibitory concentration: > 100000 nM
Compound 3 gave a limit, no number; the forecaster's own chance of this, stated with the estimate: 75%; the middle value lies beyond the limit too.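

Compound 1 and compound 3 each give only a limit, not a number, so no step can be read between them: the limit of > 100000 nM in this assay, at which 3 of the 3 values shown sit.

How strongly any of these compounds inhibits remains open, as does whether 5-chloro-2-methoxyphenyl in place of 4-methylphenyl changes that strength at all.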